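Moving the chlorine on the triazole-bound phenyl ring

This account rests on a few compounds, and the source may have more. Where it says the series, first, only, none or still open, it means among the compounds named here.

Three compounds have been measured in a functional assay on HepG2 cells (Homo sapiens) for antiproliferative activity, read by MTT assay, with a stated time of 24 h; a higher number here means a weaker inhibitor, a lower number a stronger inhibitor:

Compound 1 `O=c1[nH]cc(S(=O)(=O)Nc2ccccc2-c2cn(-c3cccc(Cl)c3)nn2)c(=O)[nH]1`: 2460 nM
Compound 2 `O=c1[nH]cc(S(=O)(=O)Nc2ccccc2-c2cn(-c3ccc(Cl)cc3)nn2)c(=O)[nH]1`: 1840 nM
Compound 3 `O=c1[nH]cc(S(=O)(=O)Nc2ccc(-c3cn(-c4cccc(Cl)c4)nn3)cc2)c(=O)[nH]1`: 2020 nM

Compound 1 and compound 2 differ only by 4-chlorophenyl in place of 3-chlorophenyl on an aromatic nitrogen. That change gave a 1.3-fold lower number from compound 1 to compound 2 (0.13 log units; within the scatter), so the two numbers cannot be told apart. Compound 3 carries a different core from compound 1; the difference between the two cores is not broken down here. Compound 4 `O=c1[nH]cc(S(=O)(=O)Nc2ccc(-c3cn(-c4ccc(Cl)cc4)nn3)cc2)c(=O)[nH]1` is related to compound 3 by the same change, (4-chlorophenyl in place of 3-chlorophenyl on an aromatic nitrogen), made at the same place.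

Because the earlier step, a 1.3-fold lower number from compound 1 to compound 2 (0.13 log units; within the scatter), stayed within the scatter, compound 4 is expected to sit close to compound 3, with an estimated step of a 1.3-fold lower number from compound 3 to compound 4 (0.10 log units; within the scatter). Compound 4 is therefore estimated at 1600 nM in this assay , most likely between 800 nM and 3500 nM.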

Compound 4, half-maximal inhibitory concentration: 1980 nM
The estimate for compound 4 lay 1.2-fold (0.09 log units) below the measured number, and the stated range covers the measured number.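

Putting 4-chlorophenyl in place of 3-chlorophenyl on the aromatic nitrogen again makes no readable difference in this assay, with a 1.0-fold lower number from compound 3 to compound 4 (0.01 log units; within the scatter). Set beside the earlier step, the change behaves alike on the two cores: the same change on two cores in this assay, a 1.3-fold lower number (0.13 log units; within the scatter) from compound 1 to compound 2 and a 1.0-fold lower number (0.01 log units; within the scatter) from compound 3 to compound 4, 1.3-fold (0.12 log units) apart, within the scatter of two such steps. Going by these compounds alone, neither step rises above the scatter, so this shows only that a change with no detectable effect on one core also has none on the other; it does not show that a real effect would carry over, nor how the change behaves on any further core.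

The compounds shown leave open whether the chlorine itself matters at all. A phenyl ring carrying a methoxy group, an amine or a carboxylic acid instead of chlorine would test that.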